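A few compounds are considered here, and "the series" means these few. Any claim that something is new, unique, unknown or untested is made for them only; others in the source may bear on it.

In a functional assay on ECa-109 cells for inhibition, with ECa-109 cell line (Homo sapiens) as the target, read by sulforhodamine B assay (on this read-out lower numbers stand for stronger inhibition and higher numbers for weaker inhibition), compound 2 `O=C1C=C(Nc2ccc(C(F)(F)F)cc2)C(=O)c2c1nc1n2[C@H]2OC[C@@H](O)[C@H]2OC1` gives 5500 nM, the only number shown for this set. Compound 1 `CCCc1ccc(NC2=CC(=O)c3nc4n(c3C2=O)[C@H]2OC[C@@H](O)[C@H]2OC4)cc1` gives > 4000 nM, which is a limit of the assay and not a number. The step that the limit leaves unreadable from compound 1 to compound 2 therefore cannot be sized. Compound 3 `O=C1C=C(Nc2cccc(Cl)c2)C(=O)c2c1nc1n2[C@H]2OC[C@@H](O)[C@H]2OC1` differs from compound 2 as follows: 3-chlorophenyl in place of 4-(trifluoromethyl)phenyl on an amine nitrogen. Among the measured compounds shown here, no measured step covers this kind of change, so no shift beyond the usual scatter is expected in either direction. The estimated step of a 1.1-fold lower number from compound 2 to compound 3 (0.04 log units; within the scatter) keeps compound 3 close to compound 2. Compound 3 is expected to give 5000 nM, between 2000 nM and 15000 nM.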

Compound 3, half-maximal inhibitory concentration: 4690 nM
Compound 3: middle estimate off by 1.1-fold (0.03 log units), on the high side; measured number inside the range.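

In this assay, among the compounds shown here, the change from 4-(trifluoromethyl)phenyl to 3-chlorophenyl on the amine nitrogen is a 1.2-fold lower number from compound 2 to compound 3 (0.07 log units; within the scatter), the only readable step in this set. At this position, these two substituted phenyl groups therefore cannot be told apart in this assay. Compound 1 carries a limit and not a number, so its steps to the other compounds cannot be read: the limit of > 4000 nM in this assay, at which 1 of the 3 values shown sits.

Going by these compounds, whether any group at this position can move the value beyond the scatter remains open. A phenyl ring bearing an amine or a carboxylic acid, or a pyridine ring, could answer that.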